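Swapping the aryl group on the triazole of compound 3

The source may hold more compounds than are shown below. What is called first, only, known or untested is meant among the compounds shown, and "the series" means these compounds.

Measured so far:
- compound 1 `CC(C)=CCC/C(C)=C/CC/C(C)=C/CC[C@@H]1[C@@]2(C)CC/C(=N\OCc3cn(-c4ccc(F)cc4)nn3)C(C)(C)[C@@H]2CC[C@@]1(C)O`: 21400 nM
- compound 2 `COc1cc(OC)c(-n2cc(CO/N=C3\CC[C@]4(C)[C@@H](CC/C=C(\C)CC/C=C(\C)CCC=C(C)C)[C@](C)(O)CC[C@H]4C3(C)C)nn2)c(OC)c1`: 12800 nM
- compound 3 `CC(C)=CCC/C(C)=C/CC/C(C)=C/CC[C@@H]1[C@@]2(C)C/C(=C\c3ccc(OCc4cn(-c5ccccc5)nn4)cc3)C(=O)C(C)(C)[C@@H]2CC[C@@]1(C)O`: 36300 nM

All three compounds share a large natural-product-like core and were tested in a functional assay on HeLa cells (Homo sapiens) for cytotoxicity, read by MTT assay, with a stated time of 48 h; a lower number here means a stronger inhibitor, a higher number a weaker inhibitor. Compound 3 gives the highest number of the three, yet its gap to compound 1 is within the scatter; only its gap to compound 2 lies beyond it. Among the measured compounds shown here, the one step that compares two measured compounds differing in a single place, a 1.7-fold lower number from compound 1 to compound 2 (0.22 log units; within the scatter), swaps one aryl group on an aromatic nitrogen for another and stays within the scatter.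

Compound 4 `CC(C)=CCC/C(C)=C/CC/C(C)=C/CC[C@@H]1[C@@]2(C)C/C(=C\c3ccc(OCc4cn(-c5c(Cl)cc([N+](=O)[O-])cc5Cl)nn4)cc3)C(=O)C(C)(C)[C@@H]2CC[C@@]1(C)O` has not yet been measured. It differs from compound 3 in one place: 2,6-dichloro-4-nitrophenyl in place of phenyl on an aromatic nitrogen. For the measured compounds named here, no measured step covers exactly this exchange; the nearest analogy is the aryl swap from compound 1 to compound 2, which did not move the number beyond the scatter.

On that basis, compound 4 is expected to stay close to compound 3, with a step of about a 1.2-fold lower number from compound 3 to compound 4 (0.08 log units; within the scatter), that is, no change beyond the scatter. The estimate for compound 4 in this assay is 30000 nM, with a range from 12000 nM to 75000 nM.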

Compound 4, half-maximal inhibitory concentration: 36900 nM
Compound 4: middle estimate off by 1.2-fold (0.09 log units), on the low side; measured number inside the range.
By their numbers in this assay, from the lowest: compounds 2, 1, 3 and 4 (each within the scatter of the next, the first and the last beyond it).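

In this assay, replacing phenyl with the much larger 2,6-dichloro-4-nitrophenyl on the aromatic nitrogen of the five-membered ring gives a 1.0-fold higher number from compound 3 to compound 4 (0.01 log units; within the scatter), so adding chlorine atoms and a nitro group leaves the number unmoved beyond the scatter. The earlier swap at this nitrogen, a 1.7-fold lower number from compound 1 to compound 2 (0.22 log units; within the scatter), was on a different core, so this result extends the same picture to the core of compound 3: in both listed steps, quite different aryl groups at this position give no change beyond the scatter in this assay. The compounds shown offer no evidence as to why this position tolerates the exchange with so little effect on the number.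

Among the compounds shown here, every group at this position so far is a substituted or plain phenyl ring, so it remains open whether an amine, a carboxylic acid or a longer alkyl chain here would shift the number beyond the scatter. As far as these compounds go, compound 1 and compound 3 differ in more than one place, so the part of the structure that does control the number in this assay also remains unknown.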